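From methylamino to methyl in compound 1

The source may report more compounds than this note shows. Statements on the series, on what has been measured and on what is new or still open speak of the compounds shown alone.

Measured in a functional assay on K562 cells (Homo sapiens), read by MTT assay, with a stated time of 72 h; on this read-out lower numbers stand for stronger inhibition and higher numbers for weaker inhibition:
- Compound 1 `CNc1ncnc2c1c(-c1ccoc1)cn2[C@@H]1O[C@H](CO)[C@@H](O)[C@H]1O`: > 20000 nM (a limit)
- Compound 2 `CNc1ncnc2c1c(-c1cc3ccccc3o1)cn2[C@@H]1O[C@H](CO)[C@@H](O)[C@H]1O`: > 20000 nM (a limit)
- Compound 3 `C#Cc1cn([C@@H]2O[C@H](CO)[C@@H](O)[C@H]2O)c2ncnc(NC)c12`: 1380 nM

Compound 1 gives no number, only a limit, and sits at the limit of > 20000 nM in this assay, at which 2 of the 3 values shown sit. Compound 4 `Cc1ncnc2c1c(-c1ccoc1)cn2[C@@H]1O[C@H](CO)[C@@H](O)[C@H]1O` keeps the furan-3-yl group of compound 1 and changes one other group: methyl in place of methylamino on an aromatic carbon. In words, this is methyl in place of methylamino on an aromatic carbon.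

For the measured compounds named here, no measured step changes that group. All three change the group that furan-3-yl occupies in compound 1: a step that the two limits leave unreadable from compound 1 to compound 2 cannot be read, while an at least 14-fold lower number from compound 1 to compound 3 (1.16 log units; beyond the scatter) and an at least 14-fold lower number from compound 2 to compound 3 (1.16 log units; beyond the scatter) are large. They bear on the new change only indirectly, showing that a single swap on the shared core can move this assay a long way. Compound 3, at 1380 nM, shows that this core can give a real number. A moderate move towards lower numbers is therefore expected, though another limit remains quite possible. The expected step is an at least 2.5-fold lower number from compound 1 to compound 4 (0.39 log units; beyond the scatter). For compound 4 the estimate is 8000 nM, with an expected range of 1000 nM to 20000 nM.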

Compound 4, half-maximal inhibitory concentration: > 20000 nM
Compound 4: no number, only a limit (the forecaster's own chance of this, stated with the estimate: 45%); middle value at least 2.5-fold (0.39 log units) away from the limit.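

Compound 1 and compound 4 each give only a limit, so the step between them cannot be read in this assay: the limit of > 20000 nM in this assay, at which 3 of the 4 values shown sit. The compounds shown leave open whether methyl in place of methylamino changes the read-out at all, and in which direction.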